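The source may hold more compounds than are shown below. What is called first, only, known or untested is meant among the compounds shown, and "the series" means these compounds.

Compound 1, `O=C(C1CC1)N1CCN(Cc2nc3ccccc3n2Cc2ccccc2C(F)(F)F)CC1`, gives the lowest number of the three measured compounds in an assay on isolated protein for inhibition of aldehyde dehydrogenase 1A1 (Homo sapiens), read by spectrophotometry, tested at 10 uM; on this read-out higher numbers stand for more inhibition at the one concentration tested (going by the name of the read-out) and lower numbers for less inhibition: compound 1 gives 56.3%, and both other numbers lie beyond the scatter above it. Compound 2, `Cc1cccc(Cn2c(CN3CCN(C(=O)CC(C)C)CC3)nc3ccccc32)c1`, gives 71.4% in this assay, and compound 3, `CC(=O)N1CCN(Cc2nc3ccccc3n2Cc2cccc(C)c2)CC1`, gives 70.3%. Among the measured compounds shown here, the one measured step, a number 1.1 percentage points lower from compound 2 to compound 3 (within the scatter), changes the amide substituent and is within the scatter.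

Compound 4, `O=C(C1CC1)N1CCN(Cc2nc3ccccc3n2Cc2ccc(F)cc2)CC1`, differs from compound 1 at the benzyl group on the shared core: 4-fluorophenyl in place of 2-(trifluoromethyl)phenyl on a saturated chain carbon bound to an aromatic nitrogen. For the measured compounds named here, no measured step exchanges one group for another at this place, so nothing bears directly on the change; compounds 2 and 3 carry a different group there, and also differ in the amide, so their values only show that the inhibition can sit higher than that of compound 1. Because compound 1 gives 56.3%, a modest rise toward the other two is expected, but the size is uncertain, so an expected step of a number 4.7 percentage points higher from compound 1 to compound 4 (within the scatter) is taken. Compound 4 is therefore estimated at 61%, with a range of 44% to 78%.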

Compound 4, a percentage reported as inhibition, at one concentration (the size of the read-out at that concentration, not a potency): 32.7%
Compound 4: middle estimate off by 28.3 percentage points, on the high side, outside the stated range (below it).
By their numbers in this assay, from the lowest: compound 4; then compound 1; then compounds 3 and 2 (each within the scatter of the next).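

Among the compounds shown here, the step at this place is a number 23.6 percentage points lower from compound 1 to compound 4 (beyond the scatter) in this assay and it is the first step to lie beyond the scatter, as the only earlier one, at the amide substituent, did not. With the cyclopropyl amide and the shared core unchanged, the read-out therefore responds to the exchange of 2-(trifluoromethyl)phenyl for 4-fluorophenyl on a saturated chain carbon bound to an aromatic nitrogen. Nothing available explains why this exchange lowers the inhibition.

The two groups differ in both substituent and ring numbering, so the compounds shown leave open which of these differences carries the step; a plain phenyl, a 2-fluorophenyl or a 4-(trifluoromethyl)phenyl group would separate them. They also leave open whether a step of this size would recur with another amide substituent, such as the acetyl group of compound 3.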